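From Methylamino to Diacetylamino on a Shared Core

A few compounds are considered here, and "the series" means these few. Any claim that something is new, unique, unknown or untested is made for them only; others in the source may bear on it.

For the measured compounds named here, compound 2 `CNc1c(C#N)[n+]([O-])c2cc(Cl)ccc2[n+]1[O-]` stands lowest of the two numbers so far in a functional assay on Ehrlich cells (Mus musculus) for cytotoxicity, read by trypan blue exclusion, with a stated time of 2 h, tested at 50 ug/mL; a lower number here means a stronger effect, a higher number a weaker effect of the compound at the concentration tested: compound 2 gives 82.7%, while compound 1 `N#Cc1c(N)[n+]([O-])c2ccc(Cl)cc2[n+]1[O-]` gives 94.3%. Going by the values given here, the single measured step, a number 11.6 percentage points lower from compound 1 to compound 2 (beyond the scatter), is the only precedent. Compound 3 `CC(=O)N(C(C)=O)c1c(C#N)[n+]([O-])c2cc(Cl)ccc2[n+]1[O-]` differs from compound 2 by diacetylamino in place of methylamino on an aromatic carbon. Since that precedent also changed the group on the same nitrogen and moved the number modestly, a modest further drop or no step beyond the scatter is expected. Compound 3 is therefore estimated at 76%, within 58% to 94%, an expected step of a number 6.7 percentage points lower from compound 2 to compound 3 (within the scatter).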

Compound 3, a percentage reported as activity, at one concentration (the size of the read-out at that concentration, not a potency): 78.9%
Estimate against measurement, compound 3: 2.9 percentage points below; the range from low to high includes it.
By their numbers in this assay, from the lowest: compounds 3 and 2 (each within the scatter of the next); then compound 1.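

In this assay, diacetylamino in place of methylamino on this aromatic carbon gives a number 3.8 percentage points lower from compound 2 to compound 3 (within the scatter), so a group without a hydrogen-bond donor and with two carbonyls leaves the read-out within the scatter of compound 2. Diacetylamino in place of amino gives a number 15.4 percentage points lower from compound 1 to compound 3 (beyond the scatter), which places compound 3, like compound 2, beyond the scatter of compound 1. Nothing available explains either step. As far as these compounds go, whether acetylamino or dimethylamino on this carbon would give a read-out close to those of compound 2 and compound 3 remains open.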